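From sec-butyl to trifluoroethyl at the carbonyl

A few compounds are considered here, and "the series" means these few. Any claim that something is new, unique, unknown or untested is made for them only; others in the source may bear on it.

In a physicochemical assay for solubility, in phosphate buffer, at pH 7.4 (on this read-out lower numbers stand for lower solubility and higher numbers for higher solubility), compound 1 `CCC(C)C(=O)N1CCC(NC(=O)Nc2ccc(C(C)C)cc2)CC1` gives 2.6 ug/mL and compound 2 `CCC(C)C(=O)N1CCC(NC(=O)Nc2ccc(C(F)(C(F)(F)F)C(F)(F)F)cc2)CC1` gives 0.17 ug/mL as the lower of the two numbers. Going by the values given here, the one measured step of a 15-fold lower number from compound 1 to compound 2 (1.18 log units; beyond the scatter) was large, but it replaced isopropyl on an aromatic carbon, a different place from the change considered here. Compound 3 `O=C(Nc1ccc(C(F)(C(F)(F)F)C(F)(F)F)cc1)NC1CCN(C(=O)CC(F)(F)F)CC1` differs from compound 2 by 2,2,2-trifluoroethyl in place of sec-butyl on a carbonyl carbon in a single change, 2,2,2-trifluoroethyl in place of sec-butyl on a carbonyl carbon. Among the compounds with values here, no measured step covers this swap, so in this assay only a small change is expected, with a 1.5-fold higher number from compound 2 to compound 3 (0.17 log units; within the scatter) as the estimated step. Compound 3 is expected near 0.25 ug/mL within a range of 0.08 ug/mL to 0.8 ug/mL in this estimate.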

Compound 3, solubility: 12.3 ug/mL
For compound 3 the middle estimate is 49-fold (1.69 log units) below the measured one; measured number above the stated range.
By their numbers in this assay, from the lowest: compound 2; then compound 1; then compound 3.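

In this assay, the group on the carbonyl carbon proves able to move the number strongly, with 2,2,2-trifluoroethyl in place of sec-butyl giving a 72-fold higher number from compound 2 to compound 3 (1.86 log units; beyond the scatter) as the step. Both measured steps bring in fluorine, yet this one runs opposite to a 15-fold lower number from compound 1 to compound 2 (1.18 log units; beyond the scatter) and so fluorine in a new group does not set the direction here. No measurement on hand accounts for the rise.

The compounds shown leave open whether the fluorine atoms or the change of chain carries the step. From the compounds shown here alone, how a plain ethyl group or an amine on the same carbonyl carbon would compare also remains open.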